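Pyridin-2-yl in place of phenyl on the shared core

This account rests on a few compounds, and the source may have more. Where it says the series, first, only, none or still open, it means among the compounds named here.

Measured compounds in a functional assay on T47D cells (Homo sapiens) for cytotoxicity, read by CCK-8 assay and cell counting, with a stated time of 2 days; on this read-out higher numbers stand for weaker inhibition and lower numbers for stronger inhibition:
Compound 1, `Oc1ccc(-c2cc(-c3cccc(Cl)c3)nc(-c3ccccn3)c2)cc1`, gives 27900 nM.
Compound 2, `Oc1ccc(-c2cc(-c3ccccc3)nc(-c3ccc(Cl)cc3)c2)cc1`, gives 4270 nM.

Compound 2 holds the lower of the two numbers, and the gap to compound 1 lies beyond the scatter. Compound 3, `Oc1ccc(-c2cc(-c3ccc(Cl)cc3)nc(-c3ccccn3)c2)cc1`, is not yet measured; it differs from compound 2 by pyridin-2-yl in place of phenyl on an aromatic carbon. Among the measured compounds shown here, no measured pair isolates this change, so the step is uncertain. Because compound 1, which also carries pyridin-2-yl, gives 27900 nM, compound 3 is expected to show a moderately weaker result, a step of a 2.3-fold higher number from compound 2 to compound 3 (0.37 log units; beyond the scatter) beyond the scatter. Compound 3 is thus estimated at 10000 nM, within 3000 nM to 35000 nM.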

Compound 3, half-maximal inhibitory concentration: 25900 nM
Compound 3: the middle estimate sits 2.6-fold (0.41 log units) below what was measured; the range from low to high includes it.
By their numbers in this assay, from the lowest: compound 2; then compounds 3 and 1 (each within the scatter of the next).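

In this assay, among the compounds shown here, pyridin-2-yl in place of phenyl on this aromatic carbon gives a 6.1-fold higher number from compound 2 to compound 3 (0.78 log units; beyond the scatter), the first reading that isolates this change, and it weakens the result. Moving the chlorine on the neighbouring aryl group gives a 1.1-fold lower number from compound 1 to compound 3 (0.03 log units; within the scatter), so 4-chlorophenyl and 3-chlorophenyl are not told apart here. Nothing available accounts for the loss. From the compounds shown here alone, whether the weakening is tied to the ring nitrogen's place remains open, as a pyridin-4-yl group at this position would show. So does whether an aminophenyl group would restore the result.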